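The compounds below may be only part of what the source reports. "The series", "measured", "known", "first", "only" and "open" are said of these compounds alone.

Of the compounds shown here, three built on a shared core have been tested in an ADME assay on HEL cells (Homo sapiens) for cytotoxicity, with a stated time of 3 days; on this read-out lower numbers stand for higher toxicity in this test and higher numbers for lower toxicity in this test. Compound 1 (`CCCCCc1ccc(-c2cc3cn([C@H]4C[C@H](O)[C@@H](CO)O4)c(=O)nc3o2)cn1`) gives > 50000 nM, which is a limit of the assay and not a number. Compound 2 (`CCCCCc1ccc(-c2cc3cn([C@H]4C[C@H](O)[C@@H](CO)O4)c(=O)nc3o2)cc1`) gives > 50000 nM, again a limit. Compound 3 (`CCCCCc1cnc(-c2cc3cn([C@H]4C[C@H](O)[C@@H](CO)O4)c(=O)nc3o2)nc1`) gives > 50000 nM, also a limit. Compound 1 therefore has no rank among the three, and the record shows only (the limit of > 50000 nM in this assay, at which 3 of the 3 values shown sit). Going by the values given here, no measured step between compounds is available, so no size of change can be read from the data directly.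

Compound 4 (`CCCCCCc1ccc(-c2cc3cn([C@H]4C[C@H](O)[C@@H](CO)O4)c(=O)nc3o2)cn1`) has not yet been measured. It differs from compound 1 by a single change: methyl in place of hydrogen on a saturated chain carbon, five bonds along the chain from an aromatic carbon.

The expectation for this change rests on the limit of compound 1, > 50000 nM. The expected step of a number no higher from compound 1 to compound 4 (the limit leaves the size open) in this assay is none beyond the scatter, with no direction foreseen, and the assay may well report only a limit again. For compound 4 the estimated value is 50000 nM, with an expected range from 25000 nM to 100000 nM.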

Compound 4, half-maximal cytotoxic concentration: > 50000 nM
Compound 4: only a limit was reported (the forecaster's own chance of this, stated with the estimate: 80%); the middle value lies on the limit itself.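

In this assay no step can be read from compound 1 to compound 4, as each of the two gives only a limit and not a number: the limit of > 50000 nM in this assay, at which 4 of the 4 values shown sit.

The compounds shown leave open how toxic any of them is in this test, and whether methyl in place of hydrogen on that saturated chain carbon changes it at all.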